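One Added Methyl on the Nitrogen Chain of Compound 1

The compounds below may be only part of what the source reports. "The series", "measured", "known", "first", "only" and "open" are said of these compounds alone.

For the measured compounds named here, in a functional assay on L1210 cells (Mus musculus) for inhibition, read by cell counting, with a stated time of 48 h (on this read-out higher numbers stand for weaker inhibition and lower numbers for stronger inhibition), compound 1 `COc1ccc(N(C)c2nc(C)nc3c2nc(C)n3C)cc1` gives 19000 nM as the only true number among the three compounds measured. Compound 2 `Cc1nc(N(C)c2ccc(OC(F)(F)F)cc2)c2nc(C)n(C)c2n1` reports > 250000 nM as a limit of the assay. Compound 3 `COc1ccc(N(C)c2ncnc3c2nc(C)n3C)cc1` reports > 250000 nM as a limit too.

Compound 4 `CCN(c1ccc(OC)cc1)c1nc(C)nc2c1nc(C)n2C` has not yet been measured. Its difference from compound 1 is methyl in place of hydrogen on a saturated chain carbon bound to a nitrogen on an aromatic ring and consists of methyl in place of hydrogen on a saturated chain carbon bound to a nitrogen on an aromatic ring, which also reads as methyl to ethyl.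

Going by the values given here, no measured step touches this place, so the two available steps bear on it only indirectly. Trifluoromethyl in place of methyl on an oxygen on an aromatic ring gives an at least 13-fold higher number from compound 1 to compound 2 (1.11 log units; beyond the scatter) as a large change beyond the scatter. Hydrogen in place of methyl on an aromatic carbon gives an at least 13-fold higher number from compound 1 to compound 3 (1.11 log units; beyond the scatter) as another large change beyond the scatter. Both moved toward weaker inhibition, so a moderate step in that same direction is expected in this assay for this single added methyl. The estimated step is a 2.4-fold higher number from compound 1 to compound 4 (0.37 log units; beyond the scatter) on this reasoning. Compound 4 is expected at 45000 nM with an estimated range of 12000 nM to 200000 nM around it.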

Compound 4, half-maximal inhibitory concentration: 35000 nM
Compound 4: middle estimate off by 1.3-fold (0.11 log units), on the high side; low and high end bracket the measured number.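

In this assay, for the compounds shown here, the first step at this place, methyl in place of hydrogen on a saturated chain carbon bound to a nitrogen on an aromatic ring, reads a 1.8-fold higher number from compound 1 to compound 4 (0.27 log units; within the scatter), so on this read-out compound 1 and compound 4 cannot be told apart. Of the three single changes made to compound 1, this is the only one that stays within the scatter, and it shows that this place accepts the step from methyl to ethyl with a true number still on the scale. Compound 2 and compound 3, by contrast, each give a limit of the assay and not a number: the limit of > 250000 nM in this assay, at which 2 of the 4 values shown sit.

The compounds shown leave open how much more this place accepts, whether a propyl or longer chain, or a chain ending in an amine or a carboxylic acid, would still read like compound 1 or would reach the limit. Also open, on these data alone, is whether the step from methyl to ethyl would read the same on compound 2 or compound 3, where a limit gives no number to start from.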